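The compounds below may be only part of what the source reports. "The series", "measured", "known", "first", "only" and "open" are said of these compounds alone.

Compound 1 `O=C(Nc1cccc(/C=C/C(=O)c2nc3ccccc3[nH]2)c1)c1ccccc1`: 8340 nM
Compound 2 `Cc1ccc(C(=O)Nc2cccc(/C=C/C(=O)c3nc4ccccc4[nH]3)c2)cc1`: 6560 nM
Compound 3 `O=C(Nc1cccc(/C=C/C(=O)c2nc3ccccc3[nH]2)c1)c1cccc(C(F)(F)F)c1`: 9570 nM

These three compounds share one core and differ only in the aromatic group attached to the amide carbonyl. In a functional assay on 143B cells (Homo sapiens) for antiproliferative activity, read by MTT assay, with a stated time of 48 h (on this read-out higher numbers stand for weaker inhibition and lower numbers for stronger inhibition), compound 3 gives 9570 nM, the highest of the three numbers, though neither a 1.1-fold higher number from compound 1 to compound 3 (0.06 log units; within the scatter) nor a 1.5-fold higher number from compound 2 to compound 3 (0.16 log units; within the scatter) goes beyond the scatter, so the three compounds cannot be told apart on this read-out.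

Compound 4 `COc1ccc(C(=O)Nc2cccc(/C=C/C(=O)c3nc4ccccc4[nH]3)c2)cc1` differs from compound 3 by 4-methoxyphenyl in place of 3-(trifluoromethyl)phenyl on a carbonyl carbon. All three measured steps bear on this change, since each of them also swaps a substituent on that same aromatic group: a 1.3-fold lower number from compound 1 to compound 2 (0.10 log units; within the scatter), a 1.1-fold higher number from compound 1 to compound 3 (0.06 log units; within the scatter) and a 1.5-fold higher number from compound 2 to compound 3 (0.16 log units; within the scatter). None of them moved the number beyond the scatter, which suggests that this part of the molecule has little say over the result, at least within the small set seen here.

Compound 4 is therefore expected to give about 7500 nM in this assay, with a likely range from 3500 nM to 16000 nM. The expected step is a 1.3-fold lower number from compound 3 to compound 4 (0.11 log units; within the scatter), no change beyond the scatter.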

Compound 4, half-maximal inhibitory concentration: 6330 nM
Compound 4: middle estimate off by 1.2-fold (0.07 log units), on the high side; measured number inside the range.
By their numbers in this assay, from the lowest: compounds 4, 2, 1 and 3 (each within the scatter of the next).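

Methoxy now joins the substituents on this aromatic group, and the number in this assay stays within the scatter at each comparison: 4-methoxyphenyl in place of 3-(trifluoromethyl)phenyl (a 1.5-fold lower number from compound 3 to compound 4 (0.18 log units; within the scatter)), methoxy in place of methyl (a 1.0-fold lower number from compound 2 to compound 4 (0.02 log units; within the scatter)) and methoxy in place of hydrogen (a 1.3-fold lower number from compound 1 to compound 4 (0.12 log units; within the scatter)). The entering 4-methoxyphenyl counts one hydrogen-bond acceptor and the leaving 3-(trifluoromethyl)phenyl counts none, yet this difference goes with no change beyond the scatter. Nothing measured here explains why these swaps leave the number in place.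

Still open, from the compounds shown here alone, is whether an amine or a carboxylic acid on this aromatic group would shift the number beyond the scatter. Going by these compounds, it is also open whether a longer chain in place of the aromatic group on the carbonyl carbon would do so.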